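This account rests on a few compounds, and the source may have more. Where it says the series, first, only, none or still open, it means among the compounds named here.

Working notes on the series. Of the compounds shown here, three of the shared core have been measured in an assay on isolated protein for inhibition of Aromatase (Homo sapiens), read by fluorescence, using NADPH, with a stated time of 30 min, tested at 50 uM; a lower number here means less inhibition, a higher number more inhibition at the concentration tested (going by the name of the read-out). Compound 1 `Cn1c(-c2ccc(Cl)c(Cl)c2)cc2ccccc21` gives 20%. Compound 2 `CN(C)c1ccc(-c2cc3ccccc3[nH]2)cc1` gives 0% in this assay, and compound 3 `COc1cccc(-c2cc3ccccc3[nH]2)c1` gives 48.4%. On these numbers compound 2 stands lowest of the three: its nearest neighbour is compound 1, whose value lies higher by a margin beyond the scatter, and compound 3 lies furthest from it, also beyond the scatter.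

Compound 4 `Cc1ccc(-c2cc3ccccc3[nH]2)cc1` has not yet been measured in this assay. It differs from compound 2 in one place: methyl in place of dimethylamino on an aromatic carbon. Among the compounds with values here, no measured pair in the set carries this same change, so the size of the step can only be judged from the numbers at hand. Compound 2, bearing dimethylamino, gives 0%, while compound 3, bearing methoxy at the corresponding carbon of its six-membered aromatic ring, gives 48.4%. Replacing dimethylamino by another small group is thus not, on this evidence, tied to a value near the floor. The step from compound 2 to compound 4 is expected to be upward and beyond the scatter, at about a number 25 percentage points higher from compound 2 to compound 4 (beyond the scatter). Compound 4 is estimated at 25%, with a range from 5% to 50%.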

Compound 4, a percentage reported as inhibition, at one concentration (the size of the read-out at that concentration, not a potency): 9.33%
Compound 4: middle estimate off by 15.7 percentage points, on the high side; the range from low to high includes it.
By their numbers in this assay, from the lowest: compounds 2 and 4 (each within the scatter of the next); then compound 1; then compound 3.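

In this assay, within the data shown here, the exchange of dimethylamino for methyl on an aromatic carbon of a six-membered aromatic ring of carbon only, para to a group of 9 heavy atoms, gives the first single-place pair of the series, and the step is a number 9.3 percentage points higher from compound 2 to compound 4 (within the scatter). Among these compounds, at this position, therefore, a group with a nitrogen and a hydrogen-bond acceptor and a smaller group of carbon only with no hydrogen-bond acceptor are not separated by this read-out, and both compounds sit in one band at the low end of the values so far. Nothing measured in the series speaks to a cause for this outcome.

The compounds shown leave open whether any group on this same aromatic carbon, such as a hydroxyl, a primary amine or a carboxylic acid, would separate from compound 2 by more than the scatter. Compound 4 differs in more than one place from compound 3, so the value of compound 3, 48.4%, cannot settle whether methoxy on this carbon would do so, nor what the place of a group on the ring contributes.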